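Arylpiperazine butylamides at the alpha-adrenergic receptor: trifluoromethylphenyl variant

The source may report more compounds than this note shows. Statements on the series, on what has been measured and on what is new or still open speak of the compounds shown alone.

In an assay on isolated protein for displacement of a labelled ligand from Alpha-1A adrenergic receptor (Homo sapiens) (a lower number here means a stronger inhibitor, a higher number a weaker inhibitor), compound 1 `Cc1cccc(N2CCN(CCCCNC(=O)c3ccc4ccccc4c3)CC2)c1C` gives 230 nM. Compound 2 `COc1ccccc1N1CCN(CCCCNC(=O)CC(C)C)CC1` gives 418 nM in this assay; the two numbers lie within the usual scatter of each other, so no order is read from them. Compound 3 `O=C(NCCCCN1CCN(c2cccc(C(F)(F)F)c2)CC1)c1ccc2ccccc2c1` is not yet measured. It differs from compound 1 by 3-(trifluoromethyl)phenyl in place of 2,3-dimethylphenyl on an amine nitrogen in a ring. Among the measured compounds shown here, no measured pair shows this change, so the step from compound 1 to compound 3 in this assay is expected to be a modest weakening, a 2.6-fold higher number from compound 1 to compound 3 (0.42 log units; beyond the scatter), though a change within the scatter cannot be excluded. For compound 3 the estimate in this assay is 600 nM, with a range from 200 nM to 1800 nM.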

Compound 3, inhibition constant: 283 nM
Beside the measured number, compound 3's estimate is 2.1-fold (0.33 log units) above it; measured number inside the range.
By their numbers in this assay, from the lowest: compounds 1, 3 and 2 (each within the scatter of the next).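

In this assay, among the compounds shown here, the first step at this position, 3-(trifluoromethyl)phenyl in place of 2,3-dimethylphenyl on the amine nitrogen in the ring gives a 1.2-fold higher number from compound 1 to compound 3 (0.09 log units; within the scatter). This exchange of phenyl substituents therefore leaves the number unchanged within the scatter for this naphthalene amide pair. No available evidence bears on this result. From the compounds shown here alone, it remains open whether an amine or a carboxylic acid on the phenyl group would move the number. The same applies to a longer chain between the amide and the ring nitrogen.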